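The source may hold more compounds than are shown below. What is called first, only, known or untested is meant among the compounds shown, and "the series" means these compounds.

In an ADME assay on BV-2 cells (Mus musculus) for cytotoxicity, with a stated time of 24 h, tested at 50 uM (on this read-out lower numbers stand for a stronger effect and higher numbers for a weaker effect at the one concentration tested), compound 1, whose structure is `COc1ccccc1S(=O)(=O)/C=C/c1ccccn1`, gives 100%. Compound 3, with the structure `COc1ccccc1S(=O)(=O)/C=C/c1cccnc1`, gives 92% in this assay. For the measured compounds named here, the only change between them is pyridin-3-yl in place of pyridin-2-yl on a double-bonded chain carbon bound to a double-bonded chain carbon, and it produced a step of a number 8 percentage points lower from compound 1 to compound 3 (within the scatter).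

Compound 2, whose structure is `COc1cccc(S(=O)(=O)/C=C/c2ccccn2)c1`, is built on a second core; how that core differs from the core of compound 1 is not broken down here. In this assay compound 2 gives 98.9%, a value within the scatter of compound 1.

Compound 4, with the structure `COc1cccc(S(=O)(=O)/C=C/c2cccnc2)c1`, has not yet been measured. It carries the same change on the core of compound 2, namely (pyridin-3-yl in place of pyridin-2-yl on a double-bonded chain carbon bound to a double-bonded chain carbon). Going by the values given here, the expected step is a number 7.9 percentage points lower from compound 2 to compound 4 (within the scatter), resting on the single earlier step of a number 8 percentage points lower from compound 1 to compound 3 (within the scatter). Compound 4 is therefore estimated at 91%, likely between 80% and 100%.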

Compound 4, a percentage reported as activity, at one concentration (the size of the read-out at that concentration, not a potency): 90.8%
Compound 4: middle estimate off by 0.2 percentage points, on the high side; low and high end bracket the measured number.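

Swapping pyridin-2-yl for pyridin-3-yl on the core of compound 2 gives, in this assay, a step of a number 8.1 percentage points lower from compound 2 to compound 4 (within the scatter). The same swap therefore reads alike on both cores: the same change on two cores in this assay, a number 8 percentage points lower (within the scatter) from compound 1 to compound 3 and a number 8.1 percentage points lower (within the scatter) from compound 2 to compound 4, 0.1 percentage points apart, within the scatter of two such steps. This shows that the step carried over between these two cores, but each step lies within the usual scatter, so it does not show that the swap has a real effect on the read-out, nor that the match would hold on any further core.

The compounds shown leave open whether an amine or a carboxylic acid in place of pyridin-2-yl would give a step beyond the scatter. They also leave open how a longer chain would read.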